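A Halogen Swap at the End of the Chain

This account rests on a few compounds, and the source may have more. Where it says the series, first, only, none or still open, it means among the compounds named here.

Among the compounds with values here, compound 2 `O=c1[nH]/c(=N\OCCCc2ccc(Br)cc2)ccn1[C@@H]1O[C@H](COP(=O)(O)OP(=O)(O)OP(=O)(O)O)[C@@H](O)[C@H]1O` stands highest of the two numbers so far in a functional assay on 1321-N1 cells for agonist activity at P2Y purinoceptor 2 (Homo sapiens), read by scintillation counting and inositol phosphate accumulation (on this read-out lower numbers stand for an effect already at smaller amounts and higher numbers for an effect only at larger amounts of compound), where compound 2 gives 350 nM. Its nearest neighbour is compound 1 `O=C(O)CCCO/N=c1/ccn([C@@H]2O[C@H](COP(=O)(O)OP(=O)(O)OP(=O)(O)O)[C@@H](O)[C@H]2O)c(=O)[nH]1`, which in this assay gives 299 nM; the step of a 1.2-fold higher number from compound 1 to compound 2 (0.07 log units; within the scatter) lies within the scatter, so no order between the two can be claimed. Compound 3 `O=c1[nH]/c(=N\OCCCc2cccc(I)c2)ccn1[C@@H]1O[C@H](COP(=O)(O)OP(=O)(O)OP(=O)(O)O)[C@@H](O)[C@H]1O` differs from compound 2 by 3-iodophenyl in place of 4-bromophenyl on a saturated chain carbon, three bonds along the chain from an oxygen. Within the data shown here, only one measured step bears on this change, and only loosely: a 1.2-fold higher number from compound 1 to compound 2 (0.07 log units; within the scatter) showed that exchanging carboxy for 4-bromophenyl at the same place on the chain left the number essentially where it was. Nothing measured speaks to exchanging one halophenyl for another, so in this assay the step is expected to fall within the scatter, in no particular direction, no change at the digits printed from compound 2 to compound 3 (within the scatter). Compound 3 is therefore estimated at 350 nM in this assay, with a range from 150 nM to 800 nM.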

Compound 3, half-maximal effective concentration: 325 nM
Compound 3: middle estimate off by 1.1-fold (0.03 log units), on the high side; low and high end bracket the measured number.
By their numbers in this assay, from the lowest: compounds 1, 3 and 2 (each within the scatter of the next).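

In this assay, the exchange of 4-bromophenyl for 3-iodophenyl gives a 1.1-fold lower number from compound 2 to compound 3 (0.03 log units; within the scatter), so the number does not register this swap of one halophenyl group for another at the end of the chain. Replacing carboxy with 3-iodophenyl at this place gives a 1.1-fold higher number from compound 1 to compound 3 (0.04 log units; within the scatter), so a second halophenyl group, like 4-bromophenyl before it, cannot be told apart from carboxy here. Nothing at hand explains why these exchanges leave the number within the scatter.

On these data alone, whether this holds for other groups at the end of the chain remains open: an amine, a plain phenyl or a pyridine might each behave differently. So might a shorter or longer chain, as all three compounds carry their end groups on the same one.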